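Chloro for Methoxy Beside a Hydroxamic Acid

The compounds below may be only part of what the source reports. "The series", "measured", "known", "first", "only" and "open" are said of these compounds alone.

Measured so far:
compound 1 `COc1ccc(C(=O)NO)cc1CNc1ccc2c(c1)cc(C)c(=O)n2C` — 68%
compound 2 `Cc1cc2cc(NS(=O)(=O)Cc3cccc(C(=O)NO)c3)ccc2n(C)c1=O` — 33%
compound 3 `COc1cc(C(=O)NO)ccc1CS(=O)(=O)Nc1ccc2c(c1)cc(C)c(=O)n2C` — 46%

In an assay on isolated protein for inhibition of protein deacetylase HDAC6 (Homo sapiens), read by fluorescence, with a stated time of 90 min, tested at 10 uM (on this read-out higher numbers stand for a stronger effect at the one concentration tested and lower numbers for a weaker effect), compound 1 gives 68%, the highest of the three numbers. Compound 3 gives 46%, a number that lies beyond the usual scatter below compound 1. Compound 2 gives 33%, the lowest of the three, also beyond the scatter below compound 1. Going by the values given here, the three compounds share a core but differ in several places at once, so no pair among them shows the effect of a single change, and no measured step can guide what follows.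

Compound 4 `Cc1cc2cc(NCc3cc(C(=O)NO)ccc3Cl)ccc2n(C)c1=O` is the next compound to be tested. It differs from compound 1 in one place only: chloro in place of methoxy on an aromatic carbon. The group that leaves, methoxy, carries one hydrogen-bond acceptor; the group that enters, chloro, carries none, and both sit on the same aromatic carbon, para to the hydroxycarbamoyl group.

Among the compounds with values here, with no comparable step among the measured compounds, the expectation rests on the small size of this change. The step of a number 8 percentage points lower from compound 1 to compound 4 (within the scatter) is expected to be small, within or only just beyond the scatter, and if anything slightly downward. Compound 4 is therefore estimated to give 60%, in a range from 40% to 78%.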

Compound 4, a percentage reported as inhibition, at one concentration (the size of the read-out at that concentration, not a potency): 84%
For compound 4 the middle estimate is 24 percentage points below the measured one; the whole stated range lies below it.
By their numbers in this assay, from the lowest: compound 2; then compound 3; then compound 1; then compound 4.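

Going by these compounds alone, at this aromatic carbon, ortho to a large group and para to a hydroxycarbamoyl group, a single exchange can now be read for the first time: in this assay, chloro in place of methoxy gives a number 16 percentage points higher from compound 1 to compound 4 (beyond the scatter). The position is therefore not indifferent to what it carries, and the methoxy group, with its hydrogen-bond acceptor and its extra heavy atom, is not required for a high read-out in this series. The read-out is taken at one concentration, so this step describes the size of the effect at that concentration and not a change in potency, and nothing measured here accounts for the rise.

The compounds shown cannot separate a gain brought by chloro from a gain brought simply by losing methoxy, and a fluoro group, a methyl group or a plain hydrogen on the same carbon would help to tell these apart. They also leave open whether the same exchange would give a similar step on another linker, as in compound 3, which carries a methoxy group of its own.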